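The source may report more compounds than this note shows. Statements on the series, on what has been measured and on what is new or still open speak of the compounds shown alone.

In a functional assay on TSGH cells (Homo sapiens) for inhibition, with a stated time of 72 h (on this read-out lower numbers stand for stronger inhibition and higher numbers for weaker inhibition), compound 1 (`COc1cc(C(=O)n2ccc3ccccc32)cc(OC)c1OC`) gives 8400 nM while compound 2 (`COc1cc(C(=O)c2ccc3[nH]ccc3c2)cc(OC)c1OC`) gives 103 nM and compound 3 (`COc1cc(C(=O)c2ccc3c(ccn3C(C)C)c2)cc(OC)c1OC`) gives 1100 nM as the middle of the three numbers. Compound 3 stands clearly apart from both other compounds, on the weaker side of compound 2 and the stronger side of compound 1.

Compound 4 (`COc1cc(C(=O)c2ccc3c(ccn3CCC(=O)O)c2)cc(OC)c1OC`) has 2-carboxyethyl in place of isopropyl on an aromatic nitrogen relative to compound 3. For the measured compounds named here, the only measured step on that nitrogen is large and points towards weaker inhibition (an 11-fold higher number from compound 2 to compound 3 (1.03 log units; beyond the scatter)). Going by the values given here, no measured compound carries 2-carboxyethyl, so this single step is the only guide and the size remains uncertain. A moderate further rise in this assay is expected, smaller than that measured step. The estimated step (a 2.7-fold higher number from compound 3 to compound 4 (0.44 log units; beyond the scatter)) carries wide margins. For compound 4 the estimated value is 3000 nM (expected range 800 nM to 12000 nM).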

Compound 4, half-maximal inhibitory concentration: > 10000 nM
Compound 4: only a limit was reported (the forecaster's own chance of this, stated with the estimate: 15%); at least 3.3-fold (0.52 log units) between middle value and limit.
By their numbers in this assay, from the lowest: compound 2; then compound 3; then compound 1. At a limit, above all of these: compound 4.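

Compound 4 is reported only as a limit of the assay: the limit of > 10000 nM in this assay, at which 1 of the 4 values shown sits. In this assay, 2-carboxyethyl in place of isopropyl on the aromatic nitrogen gives an at least 9.0-fold higher number from compound 3 to compound 4 (0.95 log units; beyond the scatter), so this position tolerates this chain even less well than isopropyl, which was the only substituent there until now. With 2-carboxyethyl in place of hydrogen the result is an at least 97-fold higher number from compound 2 to compound 4 (1.98 log units; beyond the scatter), and across the three compounds that differ at this nitrogen, both substituents shown give weaker inhibition than hydrogen, with no compound going against this.

The limit leaves the true size of the loss open, and the data cannot separate the carboxylic acid from the chain that carries it. A methyl ester of the same chain, a chain ending in an amine or a small methyl group on this nitrogen would address those questions.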